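Replacing a Benzyloxy Group with a Tert-Butylphenyl Ring

This account rests on a few compounds, and the source may have more. Where it says the series, first, only, none or still open, it means among the compounds named here.

Of the compounds shown here, two built on a shared core have been measured in an assay on CHO cells for antagonist activity at transient receptor potential cation channel subfamily V member 1 (Homo sapiens), read by FLIPR; a higher number here means a weaker inhibitor, a lower number a stronger inhibitor. Compound 1 `Cc1cccc(N2CCN(c3cc(C(F)(F)F)ccc3CNC(=O)C(C)c3ccc(NS(C)(=O)=O)c(F)c3)CC2)c1` carries an aryl piperazine on its core and in this assay compound 1 gives 1.8 nM. Compound 2 `CC(C(=O)NCc1ccc(C(F)(F)F)cc1OCc1ccccc1)c1ccc(NS(C)(=O)=O)c(F)c1` carries a benzyloxy group at the same place instead, and in this assay compound 2 gives 0.9 nM. Compound 2 shows the lower of the two numbers, yet the gap to compound 1 lies within the scatter, so neither can be called the stronger inhibitor.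

Compound 3 `CC(C(=O)NCc1ccc(C(F)(F)F)cc1-c1ccc(C(C)(C)C)cc1)c1ccc(NS(C)(=O)=O)c(F)c1` is not yet measured. It differs from compound 2 in one place: 4-(tert-butyl)phenyl in place of benzyloxy on an aromatic carbon. For the measured compounds named here, no measured pair tells how this kind of change plays out. Since compound 1, with a quite different large group at this position, gives 1.8 nM, the core seems to tolerate variation there, and compound 3 is expected to stay close to compound 2, with the step of a 2.2-fold higher number from compound 2 to compound 3 (0.35 log units; beyond the scatter) expected to be small. Compound 3 is estimated at 2 nM, with a range from 0.5 nM to 10 nM.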

Compound 3, inhibition constant: 1.1 nM
Estimate against measurement, compound 3: 1.8-fold (0.26 log units) above; measured number inside the range.
By their numbers in this assay, from the lowest: compounds 2, 3 and 1 (each within the scatter of the next).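

In this assay, 4-(tert-butyl)phenyl in place of benzyloxy gives a 1.2-fold higher number from compound 2 to compound 3 (0.09 log units; within the scatter), the first one-place step read at this aromatic carbon, meta to a trifluoromethyl group. The group that enters is all carbon and has no hydrogen-bond acceptor, while the benzyloxy group that leaves has one, so in this pair the oxygen of benzyloxy is not needed for a value at this level. Why these two groups read alike cannot be said, as no measurement on that question is at hand.

As far as these compounds go, it remains open whether a plain phenyl ring without the tert-butyl group, a small methoxy group, or a phenyl ring bearing an amine or a carboxylic acid would stay at this level. With a single step at this position, no general rule for it can yet be drawn.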